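Chloro in Place of Fluoro: an Estimate for Compound 3

A few compounds are considered here, and "the series" means these few. Any claim that something is new, unique, unknown or untested is made for them only; others in the source may bear on it.

Compound 1 `CC[C@H](NC(C)=O)c1cc(Cl)ccc1C1CCN(C(=O)[C@H]2CN(C(C)(C)C)C[C@@H]2c2ccc(F)cc2F)CC1`: 83%
Compound 2 `CC[C@H](NC(C)=O)c1cc(Cl)ccc1C1CCN(C(=O)[C@@H]2CN(C(C)(C)C)C[C@H]2c2ccc(F)cc2F)CC1`: 108%

Both measured compounds were tested in a functional assay on CHO cells for agonist activity at Melanocortin receptor 4 (Homo sapiens), read by cAMP accumulation; on this read-out lower numbers stand for smaller maximal responses and higher numbers for larger maximal responses. Compound 1 gives 83% and stands lowest of the two numbers shown, while compound 2 gives 108%. Going by the values given here, the one measured step is a number 25 percentage points higher from compound 1 to compound 2 (beyond the scatter), a modest rise that rests on (the fact that compounds 1 and 2 differ only in the configuration as drawn), since the two share every atom and bond.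

Compound 3 `CC[C@H](NC(C)=O)c1cc(Cl)ccc1C1CCN(C(=O)[C@H]2CN(C(C)(C)C)C[C@@H]2c2ccc(Cl)cc2F)CC1` differs from compound 1 by chloro in place of fluoro on an aromatic carbon. Among the compounds with values here, the measured step from compound 1 to compound 2 concerns only the drawn configuration and so says nothing about exchanging one halogen for another on the aromatic ring; no measured step bears on this change. With nothing to point either way, the expected step is none beyond the scatter: a number 2 percentage points higher from compound 1 to compound 3 (within the scatter). Compound 3 is therefore estimated at 85%, with a range from 65% to 105% in this assay.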

Compound 3, largest response reached (reported as percent of maximum), in percent of the reference or control that the assay uses: 45%
The estimate for compound 3 lay 40 percentage points above the measured number; measured number outside the range, below it.
By their numbers in this assay, from the lowest: compound 3; then compound 1; then compound 2.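

In this assay this ring carbon, para to a large group, proves sensitive to the halogen it carries: going from 2,4-difluorophenyl to 4-chloro-2-fluorophenyl brings a number 38 percentage points lower from compound 1 to compound 3 (beyond the scatter), so one atom exchanged here is enough to change the maximal response. The earlier step, a number 25 percentage points higher from compound 1 to compound 2 (beyond the scatter), involved configuration alone, whereas this result shows that a change in the substituent on the aromatic ring can also move the read-out. Nothing available here bears on the reason for this drop.

The compounds shown leave open whether chloro would lower the response in the same way in the configuration of compound 2. From the compounds shown here alone, how bromo, methyl or methoxy on this carbon would compare with fluoro and chloro also remains open.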